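From isopropoxy to a dipropylamino chain

The source may report more compounds than this note shows. Statements on the series, on what has been measured and on what is new or still open speak of the compounds shown alone.

Compound 1 `COc1cc(-c2oc3ccccc3c(=O)c2OC(C)C)cc(OC)c1OC` is the starting point in a functional assay on DU-145 cells (Homo sapiens) for antiproliferative activity, read by WST assay, with a stated time of 3 days; on this read-out higher numbers stand for weaker inhibition and lower numbers for stronger inhibition. Here compound 1 gives > 50000 nM, which is a limit of the assay and not a number. Compound 2 `CCCC(C)Oc1c(-c2cc(OC)c(OC)c(OC)c2)oc2ccccc2c1=O` gives > 50000 nM, also a limit. Between them lies a step that the two limits leave unreadable from compound 1 to compound 2. Compound 1 therefore stands at the limit of > 50000 nM in this assay, at which 2 of the 3 values shown sit.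

Compound 3 `CCN(CC)CCCCOc1c(-c2cc(OC)c(OC)c(OC)c2)oc2ccccc2c1=O`, with 4-(diethylamino)butyl on the same oxygen, gives a true number of 13300 nM. Two measured steps lead to it: an at least 3.7-fold lower number from compound 1 to compound 3 (0.57 log units; beyond the scatter), and an at least 3.7-fold lower number from compound 2 to compound 3 (0.57 log units; beyond the scatter). Both are only minimum sizes, and they rest on a single compound with a measured number.

Compound 4 `CCCN(CCC)CCCOc1c(-c2cc(OC)c(OC)c(OC)c2)oc2ccccc2c1=O` has not yet been measured. Its difference from compound 1 is 3-(dipropylamino)propyl in place of isopropyl on an oxygen on an aromatic ring. In words, this is 3-(dipropylamino)propyl in place of isopropyl on an oxygen on an aromatic ring. The entering chain carries a nitrogen, as the chain of compound 3 does, so compound 3 at 13300 nM is the closest guide. The expected change is an at least 4.5-fold lower number from compound 1 to compound 4 (0.65 log units; beyond the scatter), towards stronger inhibition and of a size like the steps to compound 3. For compound 4 the estimated value in this assay is 11000 nM, with an expected range from 3500 nM to 35000 nM.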

Compound 4, half-maximal inhibitory concentration: > 50000 nM
Compound 4 gave a limit, no number; the forecaster's own chance of this, stated with the estimate: 15%; at least 4.5-fold (0.65 log units) between middle value and limit.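

A nitrogen on the chain at this oxygen does not by itself bring a measurable effect: in this assay the change to the dipropylamino chain gives an at least 3.7-fold higher number from compound 3 to compound 4 (0.57 log units; beyond the scatter). Compound 4 gives a limit and not a number, so its steps from compound 1 and from compound 2 cannot be read, as both ends of each are limits. The activity seen with 4-(diethylamino)butyl therefore does not carry over to 3-(dipropylamino)propyl, and compound 3 remains the only compound here with a true number, while the others sit at one ceiling: the limit of > 50000 nM in this assay, at which 3 of the 4 values shown sit.

Compound 3 and compound 4 differ both in the length of the chain and in the groups on the nitrogen, and the compounds shown cannot say which of the two matters. Going by these compounds, a 3-(diethylamino)propyl or a 4-(dipropylamino)butyl group on the same oxygen would pull these apart, and a longer chain or a morpholine at the chain end also remains open.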